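This account rests on a few compounds, and the source may have more. Where it says the series, first, only, none or still open, it means among the compounds named here.

Of the compounds shown here, three of one family have so far been tested in a functional assay on the whole organism (strain Swiss albino) with Mus musculus as the target, in the maximal electroshock model, with a stated time of 4 h; a higher number here means that more compound is needed for the effect, a lower number that less compound is needed. Compound 1 `O=C(N/N=C/c1ccc(Br)cc1)Nc1cccc2ccccc12` gives 300 mg/kg in this assay. Compound 2 `CN(C)c1ccc(/C=N/NC(=O)Nc2cccc3ccccc23)cc1` gives 100 mg/kg in this assay, and compound 3 `COc1cccc(/C=N/NC(=O)Nc2cccc3ccccc23)c1` gives 300 mg/kg in this assay. Compound 3 thus stands level with compound 1, the two of them sharing the highest number of the three, while compound 2 needs less compound, as the step of a 3.0-fold lower number from compound 1 to compound 2 (0.48 log units; beyond the scatter) shows. Compound 4 `COc1ccc(OC)c(/C=N/NC(=O)Nc2cccc3ccccc23)c1` has not yet been measured. It differs from compound 3 in one place: methoxy in place of hydrogen on an aromatic carbon.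

Among the compounds with values here, two measured steps bear on this change, since both also alter only the substituted aromatic ring. The step of a 3.0-fold lower number from compound 1 to compound 2 (0.48 log units; beyond the scatter) shows that a change on that ring can move the number modestly, whereas the step of no change at the digits printed from compound 1 to compound 3 (within the scatter) shows another such change with no effect beyond the scatter. Within the data shown here, neither step adds a second methoxy group, so there is no direct precedent. A step of modest size or none seems most likely, with no clear reason to expect a particular direction. Compound 4 is therefore expected to give about 250 mg/kg in this assay, somewhere between 100 mg/kg and 600 mg/kg. The step of a 1.2-fold lower number from compound 3 to compound 4 (0.08 log units; within the scatter) is expected to stay within or close to the scatter.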

Compound 4, minimum effective dose: 300 mg/kg
Estimate against measurement, compound 4: 1.2-fold (0.08 log units) below; the measured number falls inside the stated range.
By their numbers in this assay, from the lowest: compound 2; then compounds 1, 3 and 4 (each within the scatter of the next).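

In this assay, a second methoxy group on the ring of compound 3, placed on an aromatic carbon ortho to a large group and para to a methoxy group, gives no change at the digits printed from compound 3 to compound 4 (within the scatter). This is the first step shown at this position, and it shows that hydrogen can give way to methoxy here with no shift in the required dose beyond the scatter, so compound 4 shares its printed number with compounds 1 and 3. No measurement shown here offers a reason for this flat step.

One small group at one position cannot show whether this carbon tolerates any substituent, since a hydroxy group, a carboxylic acid or a longer chain such as butoxy might still move the number in either direction. On these data alone, it also remains open whether methoxy at this position would make as little difference on a ring carrying the dimethylamino group of compound 2, which gives 100 mg/kg.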